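The compounds below may be only part of what the source reports. "The series", "measured", "known", "first", "only" and "open" are said of these compounds alone.

In an assay on isolated protein for inhibition of prostaglandin E2 receptor EP1 subtype (Homo sapiens) (a higher number here means a weaker inhibitor, a lower number a stronger inhibitor), compound 1 `O=C(O)c1cccc(C2=C(c3cc(Cl)ccc3OCc3ccccc3)CCC2)c1` gives 5.01 nM. Compound 2 `CS(=O)(=O)c1ccc(OCc2ccc(F)cc2F)c(C2=C(c3cccc(C(=O)O)c3)CCC2)c1` gives 15.9 nM in this assay, the higher of the two numbers and the weaker inhibitor of the pair, with compound 1 at a lower number beyond the usual scatter. Compound 3 `CS(=O)(=O)c1ccc(OCc2ccccc2)c(C2=C(c3cccc(C(=O)O)c3)CCC2)c1` differs from compound 2 in one place: phenyl in place of 2,4-difluorophenyl on a saturated chain carbon bound to an oxygen on an aromatic ring. For the measured compounds named here, no measured pair shows this change on its own, so the size of its effect is not known. The step from compound 2 to compound 3 is expected to be small, a 1.3-fold lower number from compound 2 to compound 3 (0.12 log units; within the scatter), in no clear direction beyond the scatter. Compound 3 is therefore estimated at 12 nM, with a range from 4 nM to 40 nM.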

Compound 3, half-maximal inhibitory concentration: 79.4 nM
Beside the measured number, compound 3's estimate is 6.6-fold (0.82 log units) below it; the measured number lies above the stated range.
By their numbers in this assay, from the lowest: compound 1; then compound 2; then compound 3.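

In this assay, phenyl in place of 2,4-difluorophenyl gives a 5.0-fold higher number from compound 2 to compound 3 (0.70 log units; beyond the scatter) and shows that the fluorines on this ring matter to the measured number, since the step lies beyond the scatter. Methylsulfonyl in place of chloro on an aromatic carbon, with the benzyl group kept, gives a 16-fold higher number from compound 1 to compound 3 (1.20 log units; beyond the scatter) and shows that this second place also responds strongly. Nothing measured here explains either step. Which of the two fluorines accounts for the first step remains open. So does whether a methoxy or nitrile group on this ring would behave like fluorine.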